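Moving the methyl on the carboxyphenyl end

This account rests on a few compounds, and the source may have more. Where it says the series, first, only, none or still open, it means among the compounds named here.

Compound 1 `Cc1c(OCCCCOc2cccc(C(=O)O)c2)ccc(C(=O)CC2CCCC2)c1O` gives 451 nM in an assay on HEK293 cells for positive allosteric modulation of metabotropic glutamate receptor 2 (Rattus norvegicus), read by thallium flux, with a stated time of 2.5 min; a higher number here means that more compound is needed for the effect, a lower number that less compound is needed. Compound 2 `COc1ccc(C(=O)O)cc1OCCCCOc1ccc(C(=O)CC2CCCC2)c(O)c1C`, which adds a methoxy on the carboxyphenyl end, gives 425 nM in this assay, the step being a 1.1-fold lower number from compound 1 to compound 2 (0.03 log units; within the scatter). Compound 3 `Cc1cc(C(=O)O)ccc1OCCCCOc1ccc(C(=O)CC2CCCC2)c(O)c1C` gives 608 nM in this assay; it holds the highest of the three numbers, yet the step of a 1.3-fold higher number from compound 1 to compound 3 (0.13 log units; within the scatter) and the step of a 1.4-fold higher number from compound 2 to compound 3 (0.16 log units; within the scatter) are both within the scatter, so no separation among the three is established.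

Compound 4 `Cc1cc(OCCCCOc2ccc(C(=O)CC3CCCC3)c(O)c2C)ccc1C(=O)O` is a rearrangement of compound 3 with the same atoms joined differently: 4-carboxy-3-methylphenyl in place of 4-carboxy-2-methylphenyl on an oxygen on a saturated carbon. Within the data shown here, the steps that bear on this change are those that altered the same carboxyphenyl end, from compound 1 to compound 3 and from compound 2 to compound 3, and each stayed within the scatter. Among the measured compounds shown here, nothing among the measured compounds tests the placement of the methyl on that ring directly, and the three measured values span less than the scatter between them. The expected step from compound 3 to compound 4 in this assay is therefore a 1.0-fold lower number from compound 3 to compound 4 (0.02 log units; within the scatter), no more than the scatter in either direction. Compound 4 is estimated to give 580 nM in this assay, with a range from 260 nM to 1300 nM.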

Compound 4, half-maximal effective concentration: 564 nM
The estimate for compound 4 lay 1.0-fold (0.01 log units) above the measured number, and the stated range covers the measured number.
By their numbers in this assay, from the lowest: compounds 2, 1, 4 and 3 (each within the scatter of the next).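

In this assay, among these compounds, the step of a 1.1-fold lower number from compound 3 to compound 4 (0.03 log units; within the scatter) is the first direct test of the placement of the methyl on the carboxyphenyl end, with 4-carboxy-3-methylphenyl in place of 4-carboxy-2-methylphenyl on an oxygen on a saturated carbon, and it does not separate the two placements. The new end is equally unseparated from the other two ends on the shared core, as shown by the step of a 1.3-fold higher number from compound 1 to compound 4 (0.10 log units; within the scatter) and the step of a 1.3-fold higher number from compound 2 to compound 4 (0.12 log units; within the scatter), so all four carboxyphenyl ends now sit within the scatter of one another and this part of the series has shown no sensitivity to these particular changes. No accompanying measurement speaks to the reason for these numbers.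

Going by these compounds, it remains open whether a larger or different group on this ring, such as a chlorine, a trifluoromethyl or a phenyl in place of the methyl, would give a step beyond the scatter. On these data alone, it is equally open whether replacing the carboxylic acid with a tetrazole or an amide, or using a shorter or longer chain between the two oxygens, would do so.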